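A few compounds are considered here, and "the series" means these few. Any claim that something is new, unique, unknown or untested is made for them only; others in the source may bear on it.

In a physicochemical assay for solubility, in phosphate buffer, with a stated time of 18 h, at pH 7 (a lower number here means a less soluble compound, a higher number a more soluble compound), compound 1 `Cc1ccc([C@@H]2[C@@H](C(=O)Nc3ccc(F)c(C#N)c3)c3ccccc3C(=O)N2CC(C)C)s1` gives < 1000 nM as a limit and not as a number. Among the compounds with values here, compound 2 `CC(C)CN1C(=O)c2ccccc2[C@H](C(=O)Nc2ccc(F)c(C#N)c2)[C@H]1c1cn[nH]c1` has a 1H-pyrazol-4-yl in place of the 5-methylthiophen-2-yl and gives 57000 nM as the only true number so far. Within the data shown here, that swap is the single measured step, an at least 57-fold higher number from compound 1 to compound 2 (1.75 log units; beyond the scatter) and it is large. Compound 3 `CC(C)CN1C(=O)c2ccccc2[C@H](C(=O)Nc2ccc(F)c(C#N)c2)[C@H]1c1cnn(C)c1` keeps the pyrazole ring of compound 2 and differs by methyl in place of hydrogen on an aromatic nitrogen with methyl in place of hydrogen on an aromatic nitrogen. This is a far smaller change than replacing a whole ring, so the step seen with compound 2 at 57000 nM serves only as a loose guide. A modest fall in this assay is expected, close to the scatter, and the estimate is a 1.9-fold lower number from compound 2 to compound 3 (0.28 log units; within the scatter) for this change. The expected value for compound 3 is 30000 nM within an estimated range from 8000 nM to 90000 nM for now.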

Compound 3, solubility: 36000 nM
Compound 3: middle estimate off by 1.2-fold (0.08 log units), on the low side; low and high end bracket the measured number.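

In this assay, methyl in place of hydrogen on the aromatic nitrogen gives a 1.6-fold lower number from compound 2 to compound 3 (0.20 log units; within the scatter), a step within the scatter, so this position takes the added carbon with no readable change. The hydrogen on that nitrogen is therefore not needed for the large step away from 5-methylthiophen-2-yl, which remains with 1-methyl-1H-pyrazol-4-yl as an at least 36-fold higher number from compound 1 to compound 3 (1.55 log units; beyond the scatter). On these data alone, the full size of that step stays unknown, as the value of compound 1 is only a limit: the limit of < 1000 nM in this assay, at which 1 of the 3 values shown sits.

Still open, as far as these compounds go, is whether a longer chain on this nitrogen, such as propyl, or a chain ending in an amine or a carboxylic acid, would also stay within the scatter of compound 2. Also open, from the compounds shown here alone, is how much of the large step comes from the thiophene ring and how much from its methyl, which plain thiophen-2-yl would help to separate.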